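The source may report more compounds than this note shows. Statements on the series, on what has been measured and on what is new or still open speak of the compounds shown alone.

Measured so far in an assay on CHO-K1 cells for displacement of a labelled ligand from prostaglandin E2 receptor EP1 subtype (Homo sapiens); a higher number here means a weaker inhibitor, a lower number a stronger inhibitor:
- compound 1 `Cc1cc(C(=O)Nc2c(F)cccc2F)nn1Cc1cc(Cl)ccc1OCc1ccccc1` gives 10 nM
- compound 2 `Cc1cc(NC(=O)CC2CCCCC2)nn1Cc1cc(Cl)ccc1OCc1ccccc1` gives 6.31 nM
- compound 3 `Cc1cc(NC(=O)C2CCOC2)nn1Cc1cc(Cl)ccc1OCc1ccccc1` gives 39.8 nM

Compound 3 holds the highest of the three numbers in this assay. Its nearest neighbour is compound 1, with a 4.0-fold higher number from compound 1 to compound 3 (0.60 log units; beyond the scatter), and the furthest is compound 2, with a 6.3-fold higher number from compound 2 to compound 3 (0.80 log units; beyond the scatter). Between compound 1 and compound 2 the step is a 1.6-fold lower number from compound 1 to compound 2 (0.20 log units; within the scatter), so those two are not distinguished by these numbers.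

Compound 4 `COC(=O)Nc1cc(C)n(Cc2cc(Cl)ccc2OCc2ccccc2)n1` differs from compound 3 at the carbonyl carbon: methoxy in place of oxolan-3-yl on a carbonyl carbon. Going by the values given here, the steps that bear on it are the two that exchanged the group on that same carbonyl carbon, a 4.0-fold higher number from compound 1 to compound 3 (0.60 log units; beyond the scatter) and a 6.3-fold higher number from compound 2 to compound 3 (0.80 log units; beyond the scatter), both of which ended in a higher number when oxolan-3-yl arrived in place of (2,6-difluorophenyl)carbamoyl or cyclohexylmethyl. Among the compounds with values here, no measured step covers methoxy on this carbonyl carbon, so the direction is not fixed by the data. Within the data shown here, the expectation is a modest further rise in the number, within the size of the earlier steps: a 1.6-fold higher number from compound 3 to compound 4 (0.20 log units; within the scatter). Compound 4 is therefore estimated at 63 nM in this assay, with a range of 20 nM to 200 nM.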

Compound 4, half-maximal inhibitory concentration: 200 nM
Estimate against measurement, compound 4: 3.2-fold (0.50 log units) below, and the stated range covers the measured number.
By their numbers in this assay, from the lowest: compounds 2 and 1 (each within the scatter of the next); then compound 3; then compound 4.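

On the carbonyl carbon, the number in this assay rises at each exchange along cyclohexylmethyl, oxolan-3-yl and methoxy: a 5.0-fold higher number from compound 3 to compound 4 (0.70 log units; beyond the scatter), and over the whole run a 32-fold higher number from compound 2 to compound 4 (1.50 log units; beyond the scatter). Against the group on the aromatic carbon in the core of compound 1, the change to (methoxycarbonyl)amino also costs a large step, a 20-fold higher number from compound 1 to compound 4 (1.30 log units; beyond the scatter), so methoxy, the only one of these groups with no ring, gives the highest number of the four. No supporting measurement accounts for this rise.

Going by these compounds, it remains open whether the loss of a ring or the oxygen of methoxy on the carbonyl carbon tracks with the higher number. An ethyl group or a longer alkyl chain on that carbon, or an amine in place of methoxy, would separate the two readings.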